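The source may report more compounds than this note shows. Statements on the series, on what has been measured and on what is new or still open speak of the compounds shown alone.

Within the data shown here, compound 2 `COc1ccc(C(=O)Nc2ccccc2F)cc1OC1CCCC1` gives 10700 nM in an assay on isolated protein for inhibition of phosphodiesterase 4A (Sus scrofa) (a lower number here means a stronger inhibitor, a higher number a weaker inhibitor), the highest of the two numbers known, while compound 1 `COc1ccc(C(=O)Nc2ccccc2C)cc1OC1CCCC1` gives 300 nM. Compound 3 `COc1ccc(C(=O)Nc2ccccc2C(F)(F)F)cc1OC1CCCC1` differs from compound 2 by trifluoromethyl in place of fluoro on an aromatic carbon. Among the measured compounds shown here, only one measured step bears on this place in the structure: a 36-fold higher number from compound 1 to compound 2 (1.55 log units; beyond the scatter). For the measured compounds named here, that step shows that exchanging the group on this aromatic carbon moved the number a long way, but no measured pair shows trifluoromethyl itself. Compound 3 is therefore expected to move part of the way back toward compound 1, a moderate lowering estimated as a 4.3-fold lower number from compound 2 to compound 3 (0.63 log units; beyond the scatter). The estimate for compound 3 is 2500 nM, within 400 nM to 15000 nM.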

Compound 3, half-maximal inhibitory concentration: 3100 nM
Compound 3: middle estimate off by 1.2-fold (0.09 log units), on the low side; the range from low to high includes it.
By their numbers in this assay, from the lowest: compound 1; then compound 3; then compound 2.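

In this assay, trifluoromethyl regains only part of the ground lost with fluoro, with a 3.5-fold lower number from compound 2 to compound 3 (0.54 log units; beyond the scatter), yet it still falls short of methyl, with a 10-fold higher number from compound 1 to compound 3 (1.01 log units; beyond the scatter). Among these three groups on this aromatic carbon, methyl therefore gives the lowest number, and fluorine on this carbon does not by itself settle the result, since the two fluorinated groups also differ. Nothing available here accounts for this order. On these data alone, it remains open whether chloro, ethyl or methoxy at this place would match methyl, and whether the same order would hold with a different group in place of the cyclopentyloxy group.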